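The source may report more compounds than this note shows. Statements on the series, on what has been measured and on what is new or still open speak of the compounds shown alone.

Measured compounds:
compound 1 `COc1cc2nc(N3CCN(c4ccncn4)CC3)nc(N)c2cc1OC` — 0.27 nM
compound 2 `COc1cc2nc(N3CCN(c4nccc(C)n4)CC3)nc(N)c2cc1OC` — 0.92 nM

In an assay on brain for binding affinity to Adrenergic receptor alpha-1 (Rattus norvegicus) (a lower number here means a stronger inhibitor, a higher number a weaker inhibitor), compound 1 gives 0.27 nM, the lowest of the two numbers. Compound 2 gives 0.92 nM; the step of a 3.4-fold higher number from compound 1 to compound 2 (0.53 log units; beyond the scatter) is the only measured one, and it swaps the whole ring on the amine nitrogen rather than adding a substituent to it.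

Compound 3 `COc1cc2nc(N3CCN(c4ccnc(Oc5ccccc5)n4)CC3)nc(N)c2cc1OC` differs from compound 1 by phenoxy in place of hydrogen on an aromatic carbon. Among the measured compounds shown here, no measured step covers the addition of a group at this place, so the bearing of the one known step is indirect: it shows only that altering this ring moves this assay by a modest amount. A similar modest shift, toward a higher number, is therefore expected, with wide uncertainty about its size.

Compound 3 is accordingly expected to give 1 nM in this assay, within 0.25 nM to 4 nM, meaning a 3.7-fold higher number from compound 1 to compound 3 (0.57 log units; beyond the scatter).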

Compound 3, inhibition constant: 0.24 nM
Compound 3: the middle estimate sits 4.2-fold (0.62 log units) above what was measured; the whole stated range lies above it.
By their numbers in this assay, from the lowest: compounds 3 and 1 (each within the scatter of the next); then compound 2.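

In this assay, phenoxy in place of hydrogen on an aromatic carbon between two ring nitrogen atoms leaves the number level, a 1.1-fold lower number from compound 1 to compound 3 (0.05 log units; within the scatter), so this place accepts a phenoxy group, with its six-membered aromatic ring of carbon only, without a shift beyond the scatter. The earlier step, a 3.4-fold higher number from compound 1 to compound 2 (0.53 log units; beyond the scatter), exchanged the whole ring on the amine nitrogen, whereas this step adds a substituent and keeps the ring of compound 1 unchanged, so a change to this ring need not move the number. Nothing available accounts for the level result.

The compounds shown leave open whether a smaller or differently built group at this place, such as an amine, a carboxylic acid or a longer alkoxy chain, also stays level with compound 1. They also leave open whether a phenoxy group would behave the same way on the 4-methylpyrimidin-2-yl ring of compound 2.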